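The compounds below may be only part of what the source reports. "The series", "measured", "known", "first", "only" and "open" are said of these compounds alone.

Compound 1 `Cc1ncnc2c1c(-c1cccs1)cn2[C@@H]1O[C@H](CO)[C@@H](O)[C@H]1O` carries a methyl on the shared core and a thiophen-2-yl on the five-membered ring. In a functional assay on HCT-116 cells (Homo sapiens), read by MTT assay, with a stated time of 72 h (on this read-out higher numbers stand for weaker inhibition and lower numbers for stronger inhibition), compound 1 gives only a limit of the assay, > 20000 nM. Compound 2 `COc1ncnc2c1c(-c1cccs1)cn2[C@@H]1O[C@H](CO)[C@@H](O)[C@H]1O` differs from compound 1 in one place, the methoxy in place of the methyl; in this assay compound 2 gives 440 nM. Among the compounds with values here, the single measured step, an at least 45-fold lower number from compound 1 to compound 2 (1.65 log units; beyond the scatter), concerns the methyl and not the aryl group, and its size rests on the limit of > 20000 nM in this assay, at which 1 of the 2 values shown sits, rather than on a number for compound 1. Compound 3 `Cc1ncnc2c1c(-c1cc3ccccc3o1)cn2[C@@H]1O[C@H](CO)[C@@H](O)[C@H]1O` keeps the methyl and changes the aryl group: 1-benzofuran-2-yl in place of thiophen-2-yl on an aromatic carbon. Within the data shown here, no measured step touches this change, so the series gives no direction for the step in this assay; what remains is that the only methyl-bearing compound, compound 1, sits at the limit. The expectation for compound 3 is therefore that it stays near that limit, a step of a number no higher from compound 1 to compound 3 (the limit leaves the size open). Compound 3 is estimated at 20000 nM, within 4000 nM to 60000 nM, with a fair chance that only a limit is again reported.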

Compound 3, half-maximal inhibitory concentration: > 20000 nM
Compound 3 gave a limit, no number; the forecaster's own chance of this, stated with the estimate: 65%; the middle value lies on the limit itself.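

In this assay compound 3 gives > 20000 nM as a limit and not a number. With compound 1 also at a limit, no new step can be read from compound 1 to compound 3: the limit of > 20000 nM in this assay, at which 2 of the 3 values shown sit. The compounds shown leave open whether 1-benzofuran-2-yl and thiophen-2-yl differ at all on the methyl-bearing core.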